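Swapping Formyl for Fluoro on the Phenyl Group

The source may hold more compounds than are shown below. What is called first, only, known or untested is meant among the compounds shown, and "the series" means these compounds.

Three compounds share one core and differ only in the group on one aromatic carbon. Compound 1 `Brc1cn2ccnc2c(-c2ccc3ncn(C4CCCCC4)c3c2)n1` carries a bromo there; in a functional assay on 786-0 cells (Homo sapiens) for inhibition, read by sulforhodamine B assay, with a stated time of 48 h, tested at 10 uM (on this read-out higher numbers stand for more inhibition at the one concentration tested (going by the name of the read-out) and lower numbers for less inhibition), compound 1 gives 10%. Compound 2 `COc1ccc(-c2cn3ccnc3c(-c3ccc4ncn(C5CCCCC5)c4c3)n2)cc1` carries a 4-methoxyphenyl, and in this assay compound 2 gives 83.2%. Compound 3 `O=Cc1ccc(-c2cn3ccnc3c(-c3ccc4ncn(C5CCCCC5)c4c3)n2)cc1` carries a 4-formylphenyl; in this assay compound 3 gives 46.7%. Compound 3 thus stands second of the three: the step of a number 36.7 percentage points higher from compound 1 to compound 3 (beyond the scatter) is large, and the step of a number 36.5 percentage points lower from compound 2 to compound 3 (beyond the scatter) is large as well, so compound 3 sits well above compound 1 and well below compound 2.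

Compound 4 `Fc1ccc(-c2cn3ccnc3c(-c3ccc4ncn(C5CCCCC5)c4c3)n2)cc1` is compound 3 with a single change: fluoro in place of formyl on an aromatic carbon. For the measured compounds named here, two measured steps bear on it. The step of a number 36.7 percentage points higher from compound 1 to compound 3 (beyond the scatter) shows that a 4-formylphenyl in place of bromo lifts inhibition strongly, and the step of a number 36.5 percentage points lower from compound 2 to compound 3 (beyond the scatter) shows that exchanging one group on that phenyl for another can move the read-out by a large amount. Fluoro has not yet been seen here, so the direction is uncertain; a modest rise toward compound 2 is expected, while a fall to the level of compound 1 is expected less, because a number 36.7 percentage points higher from compound 1 to compound 3 (beyond the scatter) was so large. The expected step is a number 13.3 percentage points higher from compound 3 to compound 4 (beyond the scatter). Compound 4 is therefore estimated at 60%, with a range from 30% to 88%.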

Compound 4, a percentage reported as inhibition, at one concentration (the size of the read-out at that concentration, not a potency): 11.2%
Beside the measured number, compound 4's estimate is 48.8 percentage points above it; the whole stated range lies above it.
By their numbers in this assay, from the lowest: compounds 1 and 4 (each within the scatter of the next); then compound 3; then compound 2.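

At this position, the phenyl ring alone does not decide the result in this assay; the group on that ring matters greatly, as fluoro in place of formyl gives a number 35.5 percentage points lower from compound 3 to compound 4 (beyond the scatter) and fluoro in place of methoxy gives a number 72 percentage points lower from compound 2 to compound 4 (beyond the scatter). The earlier compounds shown here could suggest that placing a substituted phenyl where bromo sits reliably raises inhibition, but compound 4 goes against this: 4-fluorophenyl in place of bromo gives only a number 1.2 percentage points higher from compound 1 to compound 4 (within the scatter), so compound 4 and compound 1 cannot be told apart here. Nothing available here explains why these exchanges on the phenyl ring have such large effects.

The compounds shown leave open how other groups at this ring carbon would behave, for example an amine, a carboxylic acid or a longer chain such as butoxy, and whether any of them would match the methoxy of compound 2. They also leave open how the compounds would compare across a range of concentrations, since a reading at one concentration is not a measure of potency.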